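Methylation of the Amine Nitrogen Across Two Cores

This account rests on a few compounds, and the source may have more. Where it says the series, first, only, none or still open, it means among the compounds named here.

Measured compounds:
- compound 1, `CNCC(=O)Nc1cc(OC)ccc1C(=O)c1ccc(OC)c2c1OC(C)(C)C=C2`: 620 nM in a functional assay on A549 cells (Homo sapiens) for antiproliferative activity, read by MTT assay, with a stated time of 48 h; a lower number here means a stronger inhibitor, a higher number a weaker inhibitor
- compound 2, `COc1ccc(C(=O)c2ccc(OC)c3c2OC(C)(C)C=C3)c(NC(=O)CN(C)C)c1`: 890 nM in this assay
- compound 3, `C=C(c1ccc(OC)cc1NC(=O)CN)c1ccc(OC)c2c1OC(C)(C)C=C2`: 50 nM in this assay

Compound 1 and compound 2 share one core and differ only by methyl in place of hydrogen on an amine nitrogen. That change made the step of a 1.4-fold higher number from compound 1 to compound 2 (0.16 log units; within the scatter), so the two values cannot be told apart.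

Compound 3 carries a different core; the difference between the core of compound 3 and the core of compound 1 is not broken down here. Compound 3 has the lowest of the three numbers, and its gaps to compound 1 and compound 2 both lie beyond the scatter.

Compound 4, `C=C(c1ccc(OC)cc1NC(=O)CNC)c1ccc(OC)c2c1OC(C)(C)C=C2`, is not yet measured. It differs from compound 3 by methyl in place of hydrogen on an amine nitrogen. This is the same kind of change as that from compound 1 to compound 2, not the same: there the amine nitrogen had two saturated chain carbons as its other neighbours, here it has one saturated chain carbon.

Compound 4 is expected to sit close to compound 3, with a step of about a 1.3-fold higher number from compound 3 to compound 4 (0.11 log units; within the scatter) in this assay. Among the compounds with values here, this rests on compound 3 at 50 nM and on the one earlier measured step, a 1.4-fold higher number from compound 1 to compound 2 (0.16 log units; within the scatter), which stayed within the scatter. Compound 4 is estimated at 65 nM, most likely between 30 nM and 140 nM, with a clear limit of support: one precedent only, on another core.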

Compound 4, half-maximal inhibitory concentration: 150 nM
The estimate for compound 4 lay 2.3-fold (0.36 log units) below the measured number; the measured number lies above the stated range.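

In this assay, methyl in place of hydrogen on the amine nitrogen gave a 3.0-fold higher number from compound 3 to compound 4 (0.48 log units; beyond the scatter), a modest step that can be told from the scatter, whereas a 1.4-fold higher number from compound 1 to compound 2 (0.16 log units; within the scatter) cannot. Set side by side, the two steps themselves cannot be told apart: the same change on two cores in this assay, a 1.4-fold higher number (0.16 log units; within the scatter) from compound 1 to compound 2 and a 3.0-fold higher number (0.48 log units; beyond the scatter) from compound 3 to compound 4, 2.1-fold (0.32 log units) apart, within the scatter of two such steps The readings are therefore compatible with the change carrying over between the two cores at a similar size, and they give no evidence that the core alters its effect, but they do not establish transfer, since only two steps are available and the other neighbours of the amine nitrogen are not the same in both.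

A second methyl on this nitrogen on the core of compound 3, giving the dimethylamino group already present in compound 2, would extend the comparison to the same amine on both cores. Also open, from the compounds shown here alone, is how the series responds to ethyl or a longer chain on this nitrogen, or to a cyclic amine such as pyrrolidine or morpholine in place of the open-chain amine, on either core.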